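The source may hold more compounds than are shown below. What is called first, only, known or untested is meant among the compounds shown, and "the series" means these compounds.

Measured compounds:
compound 1 `CCS(=O)(=O)Nc1cc(-c2ccc3ncnc(Nc4ccc(OC)cc4)c3c2)cnc1OC`, 3970 nM
compound 2 `CCS(=O)(=O)Nc1cc(-c2ccc3ncnc(Nc4ccc(OC)c(OC)c4)c3c2)cnc1OC`, 1680 nM

In a functional assay on SNU-638 cells (Homo sapiens) for cytotoxicity, read by sulforhodamine B assay, with a stated time of 72 h (a higher number here means a weaker inhibitor, a lower number a stronger inhibitor), compound 2 gives 1680 nM, the lowest of the two numbers recorded; its nearest neighbour is compound 1, which in this assay gives 3970 nM. Within the data shown here, the one step recorded, a 2.4-fold lower number from compound 1 to compound 2 (0.37 log units; beyond the scatter), comes from a methoxy in place of hydrogen on an aromatic carbon. Compound 3 `CCS(=O)(=O)Nc1cc(-c2ccc3ncnc(Nc4ccc(F)nc4)c3c2)cnc1OC` differs from compound 2 by 6-fluoropyridin-3-yl in place of 3,4-dimethoxyphenyl on a nitrogen on an aromatic ring. This change removes both methoxy groups that the measured step shows to help, and brings in a ring not represented among the measured compounds, so only the loss of the methoxy groups can be read from the data. Compound 3 is therefore expected to give a higher number than compound 2, with a step of about a 3.0-fold higher number from compound 2 to compound 3 (0.47 log units; beyond the scatter). The estimate for compound 3 in this assay is 5000 nM, within a range from 1500 nM to 16000 nM.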

Compound 3, half-maximal inhibitory concentration: 6520 nM
Compound 3: middle estimate off by 1.3-fold (0.12 log units), on the low side; measured number inside the range.
By their numbers in this assay, from the lowest: compound 2; then compounds 1 and 3 (each within the scatter of the next).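

Replacing the ring on the nitrogen is a larger change than the methoxy step alone: in this assay, 6-fluoropyridin-3-yl in place of 3,4-dimethoxyphenyl gives a 3.9-fold higher number from compound 2 to compound 3 (0.59 log units; beyond the scatter). Against 4-methoxyphenyl, the same group gives a 1.6-fold higher number from compound 1 to compound 3 (0.22 log units; within the scatter), so the 6-fluoropyridin-3-yl and 4-methoxyphenyl compounds cannot be told apart here, and only the 3,4-dimethoxyphenyl group stands apart from both. No evidence is available that bears on why this position responds in this way.

As far as these compounds go, the ring atoms, the fluorine and the methoxy groups all change together in this step, so their separate shares remain unknown; a plain phenyl, a fluorophenyl or a methoxypyridine would be needed to divide them. Also open, from the compounds shown here alone, is how this position would respond to an amine or a longer alkoxy chain on the ring.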